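Replacing a dinitrophenyl hydrazone with a plain phenyl hydrazone

A few compounds are considered here, and "the series" means these few. Any claim that something is new, unique, unknown or untested is made for them only; others in the source may bear on it.

Of the compounds shown here, three that share a core have been measured in a functional assay, read by spectrophotometry, with a stated time of 5 min; a higher number here means a weaker inhibitor, a lower number a stronger inhibitor. Compound 1 `O=c1cc(/C=N\c2ccc(O)cc2)c2c(OCc3ccccc3)cc(OCc3ccccc3)cc2o1` gives 249000 nM in this assay, compound 2 `O=c1cc(/C=N\Nc2ccccc2)c2ccc(OCc3ccccc3)cc2o1` gives 416000 nM, and compound 3 `O=c1cc(/C=N\Nc2ccc([N+](=O)[O-])cc2[N+](=O)[O-])c2c(OCc3ccccc3)cc(OCc3ccccc3)cc2o1` gives 292000 nM. Compound 3 holds the second highest of the three numbers, yet its gaps to compound 1 and to compound 2 both lie within the scatter, so none of the three can be set apart from the others.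

Compound 4 `O=c1cc(/C=N\Nc2ccccc2)c2c(OCc3ccccc3)cc(OCc3ccccc3)cc2o1`, not yet measured, differs from compound 3 in one place: phenyl in place of 2,4-dinitrophenyl on an amine nitrogen. Going by the values given here, no measured pair here isolates this change, so the account rests on the similar readings of compound 2 and compound 3. Compound 4 is therefore expected to show a step from compound 3 of a 1.2-fold higher number from compound 3 to compound 4 (0.08 log units; within the scatter), no larger than the scatter. Compound 4 is estimated at 350000 nM, with a range from 150000 nM to 800000 nM.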

Compound 4, half-maximal inhibitory concentration: 303000 nM
Compound 4: middle estimate off by 1.2-fold (0.06 log units), on the high side, within the range that was stated.
By their numbers in this assay, from the lowest: compounds 1, 3, 4 and 2 (each within the scatter of the next).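

Read in this assay the exchange of 2,4-dinitrophenyl for phenyl on the amine nitrogen gives a 1.0-fold higher number from compound 3 to compound 4 (0.02 log units; within the scatter) and stays within the scatter, which no earlier pair could show directly. Benzyloxy in place of hydrogen on an aromatic carbon gives a 1.4-fold lower number from compound 2 to compound 4 (0.14 log units; within the scatter) and anilino in place of 4-hydroxyphenyl on a double-bonded nitrogen gives a 1.2-fold higher number from compound 1 to compound 4 (0.09 log units; within the scatter) and both also stay within the scatter. Nothing available explains these readings. As far as these compounds go, whether an amine or a carboxylic acid on that phenyl would shift the number remains open.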